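A few compounds are considered here, and "the series" means these few. Any claim that something is new, unique, unknown or untested is made for them only; others in the source may bear on it.

Compound 1 `Cc1ccc(Cn2cc(CSc3nc(Nc4ccc(C)cc4)c(C#N)c(-c4ccccc4)n3)nn2)cc1` gives in a functional assay on MGC-803 cells (Homo sapiens) for inhibition, read by MTT assay, with a stated time of 72 h (on this read-out lower numbers stand for stronger inhibition and higher numbers for weaker inhibition), a value that is a limit, > 64000 nM.
Compound 2 `Cc1ccc(Nc2nc(SCc3cn(Cc4ccccc4Cl)nn3)nc(-c3ccc(C(C)C)cc3)c2C#N)cc1` gives in this assay a value that is also a limit, > 64000 nM.
Compound 3 `Cc1ccc(Nc2nc(SCc3cn(Cc4ccccc4Cl)nn3)nc(-c3ccc(C)cc3)c2C#N)cc1` gives in this assay 24400 nM.

Among the compounds with values here, compound 3 is therefore the one compound with a number in this assay; the values of compound 1 and of compound 2 are limits. Compound 4 `Cc1ccc(Nc2nc(SCc3cn(Cc4ccccc4Cl)nn3)nc(-c3ccc(Br)cc3)c2C#N)cc1` differs from compound 3 by one change: bromo in place of methyl on an aromatic carbon. Within the data shown here, the only measured step with a single change is an at least 2.6-fold lower number from compound 2 to compound 3 (0.41 log units; beyond the scatter), which alters the same phenyl but swaps one alkyl group for another, not methyl for bromo. Its size is known only as a lower bound, since compound 2 sits at the limit of > 64000 nM in this assay, at which 2 of the 3 values shown sit. Among the measured compounds shown here, no measured step concerns bromo. Compound 4 is therefore expected to stay near compound 3, with a wide range. For compound 4 the expected value is 22000 nM, between 6000 nM and 64000 nM. For compound 4 this means an expected step of a 1.1-fold lower number from compound 3 to compound 4 (0.04 log units; within the scatter), within the scatter, with a fair chance that only a limit is reported.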

Compound 4, half-maximal inhibitory concentration: 15600 nM
For compound 4 the middle estimate is 1.4-fold (0.15 log units) above the measured one; measured number inside the range.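

In this assay, going from 4-methylphenyl to 4-bromophenyl gives a 1.6-fold lower number from compound 3 to compound 4 (0.19 log units; within the scatter), so at this position bromo and methyl cannot be told apart. The second new step, an at least 4.1-fold lower number from compound 2 to compound 4 (0.61 log units; beyond the scatter), sets bromo clear of isopropyl on the same aromatic carbon, as methyl already was, which makes isopropyl the group that stands apart among the three. Compound 2 has a limit and not a number, so this step is known only as a lower bound: the limit of > 64000 nM in this assay, at which 2 of the 4 values shown sit.

The compounds shown leave open how a methoxy group, an amine or a carboxylic acid on this carbon would read, and whether any group here could take the number well below that of compound 4, 15600 nM. They also leave open whether bromo and methyl would stay level with other groups elsewhere on the shared core.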